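Thiophene substituent change and tolerated concentration in MDCK cells

The source may report more compounds than this note shows. Statements on the series, on what has been measured and on what is new or still open speak of the compounds shown alone.

Measured compounds:
compound 1 `Cc1ccsc1CN[C@@H]1C[C@H]2C[C@@H]([C@H]1C)C2(C)C` gives 10000 nM
compound 2 `C[C@H]1[C@H](NCc2cc(C3CC3)cs2)C[C@H]2C[C@@H]1C2(C)C` gives 25000 nM

Both compounds share the same core and differ only in the group carried on the five-membered sulfur ring. In an ADME assay on MDCK cells (Canis lupus familiaris) for cytotoxicity, read by microscopy, with a stated time of 48 h (a lower number here means that less compound is tolerated, a higher number that more compound is tolerated), compound 2 gives the highest of the two numbers, so it is the better tolerated of the pair. Compound 1 gives a lower number, and the gap between the two lies beyond the scatter of repeated measurements.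

Compound 3 `C[C@H]1[C@H](NCc2cc(-c3ccccc3)cs2)C[C@H]2C[C@@H]1C2(C)C` has not yet been measured in this assay. It differs from compound 2 in one place: phenyl in place of cyclopropyl on an aromatic carbon. Within the data shown here, no measured pair in this set shows what this kind of change does, so the expectation rests only on the two values above. A small step down is expected, a phenyl being a larger group than the cyclopropyl it replaces, but the step is expected to stay close to the scatter rather than to reach the number given by compound 1. For compound 3 the estimated step is a 1.7-fold lower number from compound 2 to compound 3 (0.22 log units; within the scatter). The estimate for compound 3 in this assay is 15000 nM, with a range from 5000 nM to 40000 nM.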

Compound 3, minimum cytotoxic concentration: 5000 nM
Compound 3: the middle estimate sits 3.0-fold (0.48 log units) above what was measured; measured number inside the range.
By their numbers in this assay, from the lowest: compounds 3 and 1 (each within the scatter of the next); then compound 2.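

In this assay, among these compounds, replacing cyclopropyl with phenyl gives a 5.0-fold lower number from compound 2 to compound 3 (0.70 log units; beyond the scatter) while the rest of the molecule stays the same, the first change in this set that can be read on its own. This shows that the group on this aromatic carbon, two ring bonds from the ring sulfur, can by itself shift how much compound MDCK cells tolerate, with less tolerated when phenyl sits there than when cyclopropyl does. The swap changes ring size and replaces a non-aromatic ring with an aromatic one at once, so this single pair cannot separate the two, and no supporting measurement explains the drop.

On these data alone, whether tolerance falls steadily as the group grows, or whether the aromatic ring itself matters, remains open, and a straight ethyl chain or a pyridyl ring at the same carbon would help to tell these apart. As far as these compounds go, it is also open whether the same swap would have a similar effect at another position on the sulfur ring, since this one pair speaks only for this position on this core.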